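Working notes: methoxy added to compound 1

This account rests on a few compounds, and the source may have more. Where it says the series, first, only, none or still open, it means among the compounds named here.

Compound 1 `CC1(/C=C/c2ccccc2)C=CC(=O)O1` measures 119000 nM
Compound 2 `CC1(/C=C/c2cccc(O)c2)C=CC(=O)O1` measures 88100 nM

Both numbers come from a functional assay on HaCaT cells (Homo sapiens) for inhibition, read by sulforhodamine B assay, with a stated time of 48 h (on this read-out lower numbers stand for stronger inhibition of growth and higher numbers for weaker inhibition of growth), and they are the only two measured so far in the series. Compound 1 stands at 119000 nM and has compound 2 as its nearest neighbour, within the scatter of it.

The next compound to be read is compound 3 `COc1ccccc1/C=C/C1(C)C=CC(=O)O1` and it keeps the core of compound 1 with one change on the aromatic ring: methoxy in place of hydrogen on an aromatic carbon.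

Among the measured compounds shown here, one measured step bears on this change. It is a 1.4-fold lower number from compound 1 to compound 2 (0.13 log units; within the scatter) for hydroxy in place of hydrogen on an aromatic carbon, and it lies within the scatter. For the measured compounds named here, no measured compound carries methoxy, so the comparison rests on that single step and on a different group. The estimate is therefore a 1.2-fold lower number from compound 1 to compound 3 (0.08 log units; within the scatter) and no step beyond the scatter is expected.

The expected value for compound 3 is 100000 nM with an estimated range from 48000 nM to 190000 nM in this assay for now.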

Compound 3, concentration for total growth inhibition: 30800 nM
Compound 3: middle estimate off by 3.2-fold (0.51 log units), on the high side; the whole stated range lies above it.
By their numbers in this assay, from the lowest: compound 3; then compounds 2 and 1 (each within the scatter of the next).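

In this assay, among the compounds shown here, methoxy in place of hydrogen on an aromatic carbon, ortho to a group of 9 heavy atoms, gives a 3.9-fold lower number from compound 1 to compound 3 (0.59 log units; beyond the scatter); this is the first step beyond the scatter, and it shows that a single small substituent on this aromatic ring of the core of compound 1 can shift the growth-inhibition number. The earlier step for hydroxy, a 1.4-fold lower number from compound 1 to compound 2 (0.13 log units; within the scatter), stayed within the scatter and gave no such sign, so the ring can no longer be read as insensitive to substitution. Nothing at hand bears on what lies behind the size of the methoxy step.

Compound 2 and compound 3 differ in both the group and its place on the ring, so the compounds shown leave open whether the step belongs to methoxy itself or to the ortho place. A hydroxy or an amine ortho to the same group, methoxy elsewhere on the ring, and a longer chain such as ethoxy at the ortho place would each help to separate these readings.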